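The compounds below may be only part of what the source reports. "The series", "measured", "known", "first", "only" and "open" are said of these compounds alone.

Of the compounds shown here, three built on the same core have been measured in a functional assay on SF-268 cells (Homo sapiens) for cytotoxicity, read by MTT assay, with a stated time of 3 days; a lower number here means a stronger inhibitor, a higher number a weaker inhibitor: compound 1 (`N#Cc1c(Nc2ccccc2)nc(SCc2nc3ccccc3[nH]2)nc1-c1ccccc1`) gives 4.46 nM, compound 2 (`N#Cc1c(Nc2ccccn2)nc(SCc2nc3ccccc3[nH]2)nc1-c1ccccc1`) gives 6.75 nM, and compound 3 (`N#Cc1c(NNC(N)=S)nc(SCc2nc3ccccc3[nH]2)nc1-c1ccccc1`) gives 3.37 nM. Compound 3 therefore stands within the scatter of both other compounds, and the three numbers cannot be ranked. The next compound is compound 4 (`N#Cc1c(-c2ccccc2)nc(SCc2nc3ccccc3[nH]2)nc1N1CCNCC1`). The structural change is a group of 6 heavy atoms (4 carbon, 2 nitrogen; one six-membered non-aromatic ring with 2 hetero atoms) in place of a group of 5 heavy atoms (1 carbon, 3 nitrogen, 1 sulfur; no ring), on an aromatic carbon: a piperazin-1-yl group enters on an aromatic carbon, ortho to a cyano group, in place of the open chain of compound 3.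

Going by the values given here, three measured steps bear on this change: a 1.5-fold higher number from compound 1 to compound 2 (0.18 log units; within the scatter), a 1.3-fold lower number from compound 1 to compound 3 (0.12 log units; within the scatter) and a 2.0-fold lower number from compound 2 to compound 3 (0.30 log units; within the scatter). Each of them stayed within the scatter, even though an open chain was exchanged for an aromatic ring in two of them. Among the compounds with values here, they bear on the new change only in part, as each swapped a group on a nitrogen on an aromatic ring, and no measured compound carries a non-aromatic ring at this place. No step beyond the scatter is therefore expected in this assay, although the uncertainty remains wide. The estimated step is a 1.5-fold higher number from compound 3 to compound 4 (0.17 log units; within the scatter). For compound 4 the estimated value is 5 nM, with an expected range from 2 nM to 14 nM.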

Compound 4, half-maximal inhibitory concentration: 20000 nM
The estimate for compound 4 lay 4000-fold (3.60 log units) below the measured number, outside the stated range (above it).
By their numbers in this assay, from the lowest: compounds 3, 1 and 2 (each within the scatter of the next); then compound 4.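

In this assay the position had accepted anilino, (pyridin-2-yl)amino and the open chain of compound 3 without any step beyond the scatter, yet piperazin-1-yl on the same aromatic carbon brings a 4500-fold higher number from compound 1 to compound 4 (3.65 log units; beyond the scatter) and a 3000-fold higher number from compound 2 to compound 4 (3.47 log units; beyond the scatter) and a 5900-fold higher number from compound 3 to compound 4 (3.77 log units; beyond the scatter) in turn. The position is therefore far from indifferent to its substituent, a sensitivity the three earlier groups had not revealed despite their differences from one another. In those groups the atom on the aromatic carbon is a nitrogen carrying a hydrogen, whereas in piperazin-1-yl that nitrogen belongs to the non-aromatic ring, but this is only a structural difference, and no available evidence explains the loss.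

The compounds shown do not separate the contributions of the ring itself, its second nitrogen and the missing hydrogen on the attached nitrogen. Piperidin-1-yl, morpholin-4-yl or an open dimethylamino group at this place, or a methyl group on the second piperazine nitrogen, would bear on that question.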